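An aryl swap on the shared core of compound 3

The source may report more compounds than this note shows. Statements on the series, on what has been measured and on what is new or still open speak of the compounds shown alone.

Compound 1 `C=CC(=O)Nc1cc(Nc2ncc(Cl)c(Nc3ccccc3S(=O)(=O)C(C)C)n2)c(OC)cc1N1CCC(N2CCN(C)CC2)CC1`: < 0.3 nM
Compound 2 `C=CC(=O)Nc1cc(Nc2ncc(Cl)c(Nc3ccccc3S(=O)(=O)C(C)C)n2)c(OC)cc1N1CCCN(C)CC1`: < 0.3 nM
Compound 3 `C=CC(=O)Nc1cc(Nc2ncc(Cl)c(Nc3ccc(F)c(Cl)c3)n2)c(OC)cc1N1CCN(C)CC1`: 300 nM

Going by the values given here, in a functional assay on NCI-H3122 cells (Homo sapiens) for inhibition, read by CellTiter-Glo, with a stated time of 72 h (on this read-out higher numbers stand for weaker inhibition of growth and lower numbers for stronger inhibition of growth), compound 3 gives 300 nM, the only number among the three measured compounds. Compound 1 reaches a limit of the assay, < 0.3 nM. Compound 2 likewise reaches a limit, < 0.3 nM. Two of the three values thus sit at the limit of < 0.3 nM in this assay, at which 2 of the 3 values shown sit. Compound 4 `C=CC(=O)Nc1cc(Nc2ncc(Cl)c(Nc3ccccc3S(=O)(=O)N(C)C)n2)c(OC)cc1N1CCN(C)CC1` has not yet been measured; it differs from compound 3 in one place: 2-(dimethylsulfamoyl)phenyl in place of 3-chloro-4-fluorophenyl on a nitrogen on an aromatic ring. Among the compounds with values here, no step between measured compounds is available, so the size of this step rests on expectation alone. The expected step, a 300-fold lower number from compound 3 to compound 4 (2.48 log units; beyond the scatter), is a large gain in this assay, well beyond the scatter. Compound 4 is estimated at 1 nM, with a range from 0.2 nM to 10 nM, and it may itself reach the limit.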

Compound 4, concentration for 50% growth inhibition: 11 nM
For compound 4 the middle estimate is 11-fold (1.04 log units) below the measured one, and the stated range ends below it.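

In this assay, this nitrogen on an aromatic ring now has a measured step, and the choice of aryl group there clearly matters: a 27-fold lower number from compound 3 to compound 4 (1.44 log units; beyond the scatter). The gain comes with a swap of a halogenated phenyl for 2-(dimethylsulfamoyl)phenyl, which brings 2 hydrogen-bond acceptors. Compound 4 still gives a number that can be read, clear of the limit: the limit of < 0.3 nM in this assay, at which 2 of the 4 values shown sit.

Going by these compounds, how much of the step belongs to the sulfamoyl group, and how much to the loss of chlorine and fluorine, stays open. On these data alone, whether a 2-(methylsulfonyl)phenyl or a 2-carbamoylphenyl group would serve equally well at this place also stays open.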